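This account rests on a few compounds, and the source may have more. Where it says the series, first, only, none or still open, it means among the compounds named here.

Of the compounds shown here, three sharing one core have been tested in an assay on membranes from brain for binding affinity to adenosine receptor A1 (Rattus norvegicus), read by radioligand binding; on this read-out higher numbers stand for weaker inhibition and lower numbers for stronger inhibition. Compound 1 `Cc1nn(C)c2c(O)nc(-c3cccnc3)nc12` gives 3090 nM. Compound 2 `CCn1nc(C)c2nc(-c3ccccc3)nc(O)c21` gives 670 nM. Compound 3 `Cc1nn(C)c2c(O)nc(-c3ccccc3)nc12` gives 1020 nM. Compound 3 thus stands second highest of the three, nearest compound 2 and furthest from compound 1: a 3.0-fold lower number from compound 1 to compound 3 (0.48 log units; beyond the scatter), whereas a 1.5-fold higher number from compound 2 to compound 3 (0.18 log units; within the scatter). Compound 4 `Cc1ccc(-c2nc(O)c3c(n2)c(C)nn3C)cc1` differs from compound 3 by methyl in place of hydrogen on an aromatic carbon. Among the measured compounds shown here, no measured step alters a substituent on that ring; only the step from compound 1 to compound 3, which exchanges the ring itself, bears on it, and it was modest. A small step in this assay is therefore expected, with no firm direction. For compound 4 the estimate is 800 nM, between 300 nM and 2500 nM, which would mean a 1.3-fold lower number from compound 3 to compound 4 (0.11 log units; within the scatter).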

Compound 4, half-maximal inhibitory concentration: 400 nM
Compound 4: the middle estimate sits 2.0-fold (0.30 log units) above what was measured, and the stated range covers the measured number.
By their numbers in this assay, from the lowest: compounds 4, 2 and 3 (each within the scatter of the next, the first and the last beyond it); then compound 1.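

With the ring kept, methyl in place of hydrogen, para to a large group, gives a 2.6-fold lower number from compound 3 to compound 4 (0.41 log units; beyond the scatter) in this assay. Among the compounds shown here, the earlier compounds had touched this ring only by exchanging it, so this is the first sign that a single substituent there can move the number beyond the scatter, here downward. Nothing available explains the shift. Going by these compounds, whether ethyl, methoxy or chlorine at the same place would lower the number further remains open. So does whether methyl would act alike on the core of compound 2.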